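Urea series on a shared benzylpiperidine core

A few compounds are considered here, and "the series" means these few. Any claim that something is new, unique, unknown or untested is made for them only; others in the source may bear on it.

compound 1 `O=C(Nc1ccccc1)Nc1ccccc1CN1CCC(Cc2ccccc2)CC1`: > 10000 nM
compound 2 `COc1cccc(NC(=O)Nc2ccccc2CN2CCC(Cc3ccccc3)CC2)c1`: > 10000 nM

In an in vitro assay on CHO cells for inhibition of C-C chemokine receptor type 1 (Homo sapiens) (a higher number here means a weaker inhibitor, a lower number a stronger inhibitor), compound 1 gives only a limit, > 10000 nM. Compound 2 likewise gives only a limit, > 10000 nM. The step that the two limits leave unreadable from compound 1 to compound 2 cannot be read, since both values sit at the limit of > 10000 nM in this assay, at which 2 of the 2 values shown sit. Compound 3 `O=C(Nc1ccc2[nH]ncc2c1)Nc1ccccc1CN1CCC(Cc2ccccc2)CC1` carries the change (1H-indazol-5-yl in place of 3-methoxyphenyl on an amide-type nitrogen). Among the compounds with values here, no measured step bears on this change; the single step known, from compound 1 to compound 2, is unreadable, so no direction can be taken from it. A move into measurable binding is nonetheless expected, an at least 3.3-fold lower number from compound 2 to compound 3 (0.52 log units; beyond the scatter), with wide uncertainty. Compound 3 is estimated at 3000 nM, between 300 nM and 30000 nM.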

Compound 3, half-maximal inhibitory concentration: > 10000 nM
Compound 3: only a limit was reported; the forecaster's own chance of this, stated with the estimate: 50%; at least 3.3-fold (0.52 log units) between middle value and limit.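

In this assay compound 3 also gives only a limit, > 10000 nM. Within the data shown here, no step among compound 1, compound 2 and compound 3 can be read: the limit of > 10000 nM in this assay, at which 3 of the 3 values shown sit. As far as these compounds go, whether phenyl, 3-methoxyphenyl or 1H-indazol-5-yl on the amide-type nitrogen differ in binding remains open.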